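The source may report more compounds than this note shows. Statements on the series, on what has been measured and on what is new or still open speak of the compounds shown alone.

Measured so far in an ADME assay on MT4 cells (Homo sapiens) for cytotoxicity, read by XTT assay, with a stated time of 5 days (a lower number here means that less compound is tolerated, a higher number that more compound is tolerated), with all three readings being limits of the assay:

Compound 1 `COC(=O)N[C@H](C(=O)NN(CC[C@@](O)(Cc1ccccc1)C(=O)N[C@H]1c2ccccc2C[C@H]1O)Cc1ccc(-c2cc(F)cc(F)c2)cc1)C(C)(C)C`: > 10000 nM
Compound 2 `COC(=O)N[C@H](C(=O)NN(CC[C@@](O)(Cc1ccccc1)C(=O)N[C@H]1c2ccccc2C[C@H]1O)Cc1ccc(-c2c(C)noc2C)cc1)C(C)(C)C`: > 10000 nM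
Compound 3 `COC(=O)N[C@H](C(=O)NN(CC[C@@](O)(Cc1ccccc1)C(=O)N[C@H]1c2ccccc2C[C@H]1O)Cc1ccc(-c2cnn(C)c2)cc1)C(C)(C)C`: > 10000 nM

Compound 3 gives > 10000 nM, which is a limit and not a number. The whole set shows (the limit of > 10000 nM in this assay, at which 3 of the 3 values shown sit), so compound 3 has no exact place within it.

The next compound is compound 4 `COC(=O)N[C@H](C(=O)NN(CC[C@@](O)(Cc1ccccc1)C(=O)N[C@H]1c2ccccc2C[C@H]1O)Cc1ccccc1)C(C)(C)C`, and the change is hydrogen in place of 1-methyl-1H-pyrazol-4-yl on an aromatic carbon. In words, this is hydrogen in place of 1-methyl-1H-pyrazol-4-yl on an aromatic carbon, para to a large group. Cut one bond further out, 4-(1-methyl-1H-pyrazol-4-yl)phenyl becomes phenyl.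

Within the data shown here, three measured steps bear on this change: a step that the two limits leave unreadable from compound 1 to compound 2, a step that the two limits leave unreadable from compound 1 to compound 3 and a step that the two limits leave unreadable from compound 2 to compound 3. Each swaps one group for another on an aromatic carbon, and none replaces the group with hydrogen. Their sizes cannot be read, so they offer no measured guide to the size of the new step. Even so, no step beyond the scatter is expected in this assay, because the limit of > 10000 nM in this assay, at which 3 of the 3 values shown sit, and compound 4 will most likely be reported at that limit too. The expected change is a step that the limit leaves unreadable from compound 3 to compound 4. For compound 4 the estimated value is 15000 nM, with an expected range from 8000 nM to 40000 nM.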

Compound 4, half-maximal cytotoxic concentration: > 10000 nM
Compound 4 gave a limit, no number; the forecaster's own chance of this, stated with the estimate: 85%; the middle value is on the limit's open side.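

In this assay compound 4 gives > 10000 nM, which is a limit and not a number. The steps to compound 4 from compound 1, compound 2 and compound 3 cannot be read, and the whole set now shows: the limit of > 10000 nM in this assay, at which 4 of the 4 values shown sit.

The compounds shown leave open at what concentration any of them would harm these cells, and whether the group on the aromatic carbon makes any difference to that.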